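This account rests on a few compounds, and the source may have more. Where it says the series, first, only, none or still open, it means among the compounds named here.

For the measured compounds named here, compound 2 `Nc1scc(CN2CCN(c3ccc(F)cc3F)CC2)c1C(=O)c1ccc(Cl)cc1` holds the higher of the two numbers so far in a functional assay on CHO cells with adenosine receptor A1 (Homo sapiens) as the target, read by cAMP accumulation and immunoassay, with a stated time of 6 min, tested at 0.01 uM (a higher number here means a weaker effect of the compound at the concentration tested, a lower number a stronger effect), where compound 2 gives 0%; the nearest is compound 1 `COc1ccc(N2CCN(Cc3csc(N)c3C(=O)c3ccc(Cl)cc3)CC2)cc1`, which in this assay gives -1.2%, and the gap between the two is within the scatter. Compound 3 `Nc1scc(CN2CCN(c3cc(F)cc(F)c3)CC2)c1C(=O)c1ccc(Cl)cc1` differs from compound 2 only on the amine nitrogen in the ring: 3,5-difluorophenyl in place of 2,4-difluorophenyl on an amine nitrogen in a ring. Going by the values given here, the one measured step that bears on this change, a number 1.2 percentage points higher from compound 1 to compound 2 (within the scatter), also exchanged the aryl group on that same ring nitrogen and stayed within the scatter. Among the compounds with values here, nothing measured so far separates one difluorophenyl pattern from another at this position, and both aryl groups tried gave essentially no effect at the tested concentration. For compound 3 the expected step is therefore no change at the digits printed from compound 2 to compound 3 (within the scatter), none beyond the scatter. Compound 3 is estimated at 0% in this assay, with a range from -10% to 10%.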

Compound 3, a percentage reported as activity, at one concentration (the size of the read-out at that concentration, not a potency): -13%
For compound 3 the middle estimate is 13 percentage points above the measured one; the measured number lies below the stated range.
By their numbers in this assay, from the lowest: compound 3; then compounds 1 and 2 (each within the scatter of the next).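

In this assay the fluorine pattern on the aryl group at this ring nitrogen makes a measurable difference: 3,5-difluorophenyl in place of 2,4-difluorophenyl, with the same atoms joined differently, gives a number 13 percentage points lower from compound 2 to compound 3 (beyond the scatter) as a modest step beyond the scatter. Replacing 4-methoxyphenyl with 3,5-difluorophenyl gives a number 11.8 percentage points lower from compound 1 to compound 3 (beyond the scatter) while replacing it with 2,4-difluorophenyl gives a number 1.2 percentage points higher from compound 1 to compound 2 (within the scatter) so across these three compounds the shift goes with the 3,5-difluorophenyl group and not with the presence of fluorine alone. No available evidence accounts for this difference.

Going by these compounds, whether a chlorophenyl, a trifluoromethylphenyl or a pyridine ring at this nitrogen would extend the shift remains open. On these data alone, these are read-outs at a single concentration, so potency at the receptor also remains open.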